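The source may hold more compounds than are shown below. What is called first, only, known or untested is meant among the compounds shown, and "the series" means these compounds.

Compound 1 `C#Cc1cn([C@@H]2O[C@H](CO)[C@@H](O)[C@H]2O)c2ncnc(C)c12` stands lowest of the two numbers in a functional assay on HepG2 cells (Homo sapiens) for antiproliferative activity, read by XTT assay, with a stated time of 72 h (on this read-out lower numbers stand for stronger inhibition and higher numbers for weaker inhibition), where compound 1 gives 290 nM. Compound 3 `Cc1ncnc2c1c(-c1ccsc1)cn2[C@@H]1O[C@H](CO)[C@@H](O)[C@H]1O` gives 4720 nM in this assay. Compound 2 `Cc1ncnc2c1c(-c1cccs1)cn2[C@@H]1O[C@H](CO)[C@@H](O)[C@H]1O` reaches only a limit in this assay, > 15000 nM; this value sits at the limit of > 15000 nM in this assay, at which 1 of the 3 values shown sits. The steps away from compound 1 are an at least 51-fold higher number from compound 1 to compound 2 (1.71 log units; beyond the scatter) and a 16-fold higher number from compound 1 to compound 3 (1.21 log units; beyond the scatter); between the two thiophenyl compounds the step is an at least 3.1-fold lower number from compound 2 to compound 3 (0.50 log units; beyond the scatter). Compound 4 `C#Cc1cn([C@@H]2O[C@H](CO)[C@@H](O)[C@H]2O)c2ncnc(OC)c12` differs from compound 1 in methoxy in place of methyl on an aromatic carbon. Among the measured compounds shown here, none of the measured steps bears on this change: all three exchange the ethynyl group, while the methyl group is the same in compound 1, compound 2 and compound 3. The ethynyl group, which goes with the lowest number in this assay, is kept in compound 4. For the measured compounds named here, with no measured step at the methyl group, only a step within or near the scatter is expected for a 2.1-fold higher number from compound 1 to compound 4 (0.32 log units; beyond the scatter). For compound 4 the expected value in this assay is 600 nM, within 150 nM to 3000 nM.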

Compound 4, half-maximal inhibitory concentration: 12700 nM
For compound 4 the middle estimate is 21-fold (1.33 log units) below the measured one; the whole stated range lies below it.
By their numbers in this assay, from the lowest: compound 1; then compound 3; then compound 4. At a limit, above all of these: compound 2.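

In this assay, among the compounds shown here, methoxy in place of methyl gives a 44-fold higher number from compound 1 to compound 4 (1.64 log units; beyond the scatter), so the position next to the ring nitrogen, which stayed the same in the earlier compounds, proves sensitive to change. Keeping the ethynyl group therefore does not by itself hold the number low: compound 1 and compound 4 both carry it, and in this pair the low number also depends on the methyl group. Nothing measured here bears on the reason for this step.

Open, as far as these compounds go, is whether an amine, an ethyl group or a longer alkoxy chain at this position would stay close to compound 1 or follow compound 4. Also open, from the compounds shown here alone, is whether the methoxy step holds with thiophen-3-yl in place of ethynyl, since methoxy appears here only alongside the ethynyl group.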